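This account rests on a few compounds, and the source may have more. Where it says the series, first, only, none or still open, it means among the compounds named here.

Compound 1 `COc1cc(-c2cccc3nc(-c4ccccc4)oc23)cc(OC)c1OC` is one of three close relatives tested in a functional assay on NCI-H460 cells (Homo sapiens) for antiproliferative activity, read by MTT assay, with a stated time of 48 h (a lower number here means a stronger inhibitor, a higher number a weaker inhibitor), where compound 1 gives 6800 nM. This is the higher of the two plain numbers: compound 3 `COc1cc(-c2cccc3nc(-c4ccc(C)cc4)oc23)cc(OC)c1OC` gives 1900 nM, a step of a 3.6-fold lower number from compound 1 to compound 3 (0.55 log units; beyond the scatter). Compound 2 `COc1cccc(-c2nc3cccc(-c4cc(OC)c(OC)c(OC)c4)c3o2)c1` reaches only a limit of the assay, > 25000 nM. That means an at least 3.6-fold higher number from compound 1 to compound 2 (0.56 log units; beyond the scatter) and an at least 13-fold lower number from compound 2 to compound 3 (1.11 log units; beyond the scatter).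

Compound 4 `COc1cc(-c2cccc3nc(-c4ccc(N)cc4)oc23)cc(OC)c1OC` differs from compound 1 in one place: amino in place of hydrogen on an aromatic carbon. Adding one small group to the same phenyl ring thus moved the number in either direction before, so the expected step is small or none beyond the scatter, and compound 4 is estimated at 3500 nM, between 1000 nM and 12000 nM, meaning a 1.9-fold lower number from compound 1 to compound 4 (0.29 log units; within the scatter).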

Compound 4, half-maximal inhibitory concentration: 310 nM
The estimate for compound 4 lay 11-fold (1.05 log units) above the measured number, and the stated range ends above it.
By their numbers in this assay, from the lowest: compound 4; then compound 3; then compound 1. At a limit, above all of these: compound 2.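

At this place, para to a large group, amino brings a 22-fold lower number from compound 1 to compound 4 (1.34 log units; beyond the scatter) and is the largest gain seen on this ring. Amino also outdoes methyl at the same place with a 6.1-fold lower number from compound 3 to compound 4 (0.79 log units; beyond the scatter) so the identity of the entering group matters here, not merely that a group enters. The step of an at least 80-fold lower number from compound 2 to compound 4 (1.90 log units; beyond the scatter) is only a bound, since it starts from a limit: the limit of > 25000 nM in this assay, at which 1 of the 4 values shown sits.

The compounds shown do not tell why amino stands out. Going by these compounds, whether a hydroxyl, a methylamino or an acetamido group at this place would match it remains open.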